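Carbonyl Substituent Change Gauged Against Three Measurements

The source may hold more compounds than are shown below. What is called first, only, known or untested is meant among the compounds shown, and "the series" means these compounds.

Measured compounds in a functional assay on HepG2 cells (Homo sapiens) for inhibition, read by scintillation counting, with a stated time of 2 h; on this read-out lower numbers stand for stronger inhibition and higher numbers for weaker inhibition:
Compound 1 `CC(=O)N1CCC(C(=O)N2CCC(N3CCN(C(=O)c4cc(-c5ccc(C)cc5)nc(-c5ccc6[nH]c(C)c(C)c6c5)c4)CC3)CC2)CC1`: compound 1 gives 294 nM.
Compound 2 `CCNC(=O)Nc1sc2ccccc2c1C(=O)N1CCN(C2CCN(C(=O)C3CCCC3)CC2)CC1`: compound 2 gives 309 nM.
Compound 3 `CCNC(=O)Nc1sc2ccccc2c1C(=O)N1CCN(C2CCN(C(=O)C(C)(C)C)CC2)CC1`: compound 3 gives 450 nM.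

Compound 3 shows the highest of the three numbers, yet its nearest neighbour, compound 2, sits within the scatter, and compound 1, the furthest, also lies within the scatter, so the three cannot be placed in order. Compound 4 `CCNC(=O)Nc1sc2ccccc2c1C(=O)N1CCN(C2CCN(C(=O)OC(C)(C)C(F)(F)F)CC2)CC1` differs from compound 3 in one place: 1-methyl-1-(trifluoromethyl)ethoxy in place of tert-butyl on a carbonyl carbon. For the measured compounds named here, one measured step touches the same carbonyl carbon: a 1.5-fold higher number from compound 2 to compound 3 (0.16 log units; within the scatter), a change that stayed within the scatter. Going by the values given here, no measured pair shows an alkoxy group or fluorine entering at this position, so the step from compound 3 to compound 4 rests on that single neighbouring comparison. Since variation on this carbonyl has so far moved this assay little, the number for compound 4 is expected to stay close to that of compound 3, with no change at the digits printed from compound 3 to compound 4 (within the scatter) expected. Compound 4 is therefore estimated at 450 nM, within the range 150 nM to 1400 nM.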

Compound 4, half-maximal inhibitory concentration: 81 nM
For compound 4 the middle estimate is 5.6-fold (0.74 log units) above the measured one; measured number outside the range, below it.
By their numbers in this assay, from the lowest: compound 4; then compounds 1, 2 and 3 (each within the scatter of the next).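

In this assay this carbonyl carbon proved able to move the number beyond the scatter, with a 5.6-fold lower number from compound 3 to compound 4 (0.74 log units; beyond the scatter) and, against the cyclopentyl group, a 3.8-fold lower number from compound 2 to compound 4 (0.58 log units; beyond the scatter). For the compounds shown here, the only earlier step at this position, a 1.5-fold higher number from compound 2 to compound 3 (0.16 log units; within the scatter), had stayed within the scatter, so a swap between the two carbon-linked groups had not revealed this sensitivity, whereas 1-methyl-1-(trifluoromethyl)ethoxy now does. Nothing available here explains the shift.

The entering group brings oxygen and fluorine together, and the compounds shown do not separate the two, so it remains open how much of the step a plain tert-butoxy group on the same carbonyl carbon would keep. Also open, as far as these compounds go, is whether the same group would give a comparable step on the core of compound 1.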